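Compound 3 to compound 4: methoxy in place of chloro

The source may hold more compounds than are shown below. What is called first, only, known or untested is meant among the compounds shown, and "the series" means these compounds.

In an ADME assay on HEK-293T cells (Homo sapiens) for cytotoxicity, read by CCK-8 assay, with a stated time of 48 h (on this read-out higher numbers stand for weaker inhibition and lower numbers for stronger inhibition), compound 1 `O=C(NCCNS(=O)(=O)c1ccc(-c2ccccc2Oc2ccc([N+](=O)[O-])c([N+](=O)[O-])c2)s1)Nc1cc(Cl)cc(Cl)c1` gives > 20000 nM, which is a limit and not a number. Compound 3 `O=C(NCCNS(=O)(=O)c1ccc(-c2ccccc2Oc2ccc([N+](=O)[O-])c([N+](=O)[O-])c2)s1)Nc1ccc(Cl)cc1` gives > 20000 nM, again a limit. Compound 3 therefore stands at the limit of > 20000 nM in this assay, at which 2 of the 3 values shown sit. Among the measured compounds shown here, compound 2 `O=C(NCCNS(=O)(=O)c1ccc(-c2ccccc2Oc2ccc([N+](=O)[O-])c([N+](=O)[O-])c2)s1)Nc1ccc([N+](=O)[O-])cc1` gives 16600 nM, the only actual number so far.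

Compound 4 `COc1ccc(NC(=O)NCCNS(=O)(=O)c2ccc(-c3ccccc3Oc3ccc([N+](=O)[O-])c([N+](=O)[O-])c3)s2)cc1` carries methoxy in place of chloro on an aromatic carbon, para to a large group: methoxy in place of chloro on an aromatic carbon.

The closest measured change, chloro in place of nitro on an aromatic carbon, gave an at least 1.2-fold higher number from compound 2 to compound 3 (0.08 log units; that floor lies within the scatter). Replacing 3,5-dichlorophenyl with 4-nitrophenyl gave an at least 1.2-fold lower number from compound 1 to compound 2 (0.08 log units; that floor lies within the scatter). Replacing 3,5-dichlorophenyl with 4-chlorophenyl gave a step that the two limits leave unreadable from compound 1 to compound 3. No measured step involves methoxy, and none of these steps is shown to exceed the scatter, so no shift beyond the scatter is expected in this assay.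

The expected step is a number no higher from compound 3 to compound 4 (the limit leaves the size open). For compound 4 the estimated value is 20000 nM, with an expected range of 11000 nM to 36000 nM.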

Compound 4, half-maximal inhibitory concentration: 18500 nM
Compound 4: the middle estimate sits 1.1-fold (0.03 log units) above what was measured; low and high end bracket the measured number.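

In this assay, methoxy and nitro at this place on the ring can now be compared on actual numbers, and methoxy in place of nitro gave a 1.1-fold higher number from compound 2 to compound 4 (0.05 log units; within the scatter). Against the chloro-bearing compounds only floors can be read: methoxy in place of chloro gave an at least 1.0-fold lower number from compound 3 to compound 4 (0.03 log units; that floor lies within the scatter), and 4-methoxyphenyl in place of 3,5-dichlorophenyl gave an at least 1.0-fold lower number from compound 1 to compound 4 (0.03 log units; that floor lies within the scatter). No step at this place is shown to exceed the scatter, and the series stays close to a limit of the assay: the limit of > 20000 nM in this assay, at which 2 of the 4 values shown sit.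

Going by these compounds, how far compound 1 and compound 3 lie past that limit remains unknown. Also open, on these data alone, is whether an amine or a carboxylic acid at this place would give a step beyond the scatter in this assay.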